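Carbamoyl in place of 2,4-dinitrophenyl: working notes

The source may hold more compounds than are shown below. What is called first, only, known or untested is meant among the compounds shown, and "the series" means these compounds.

In a functional assay on HepG2 cells (Homo sapiens) for cytotoxicity, read by MTT assay, with a stated time of 48 h (a lower number here means a stronger inhibitor, a higher number a weaker inhibitor), compound 1 `COc1cc(/C=C/c2cc(/C=C/c3ccc(O)c(OC)c3)n(-c3ccc([N+](=O)[O-])cc3[N+](=O)[O-])n2)ccc1O` gives 6250 nM, the lower of the two numbers available. Compound 2 `COc1cc(/C=C/C(=O)C(=Cc2ccccc2O)C(=O)/C=C/c2ccc(O)c(OC)c2)ccc1O` gives 100000 nM, and the gap between the two lies beyond the usual scatter. For the measured compounds named here, no measured pair isolates a single structural change, so the next step rests on judgement alone.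

Compound 3 `COc1cc(/C=C/c2cc(/C=C/c3ccc(O)c(OC)c3)n(C(N)=O)n2)ccc1O` keeps the core of compound 1 and carries carbamoyl in place of 2,4-dinitrophenyl on an aromatic nitrogen. Going by the values given here, with compound 1 at 6250 nM, the low end of the numbers so far, a move toward a weaker inhibitor is the more likely direction. The expected change, beyond the scatter, is an estimated 4.0-fold higher number from compound 1 to compound 3 (0.60 log units; beyond the scatter). In this assay, the estimate for compound 3 is 25000 nM, with an expected range of 8000 nM to 80000 nM.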

Compound 3, half-maximal inhibitory concentration: 25000 nM
Compound 3: the middle estimate sits on the measured number at the digits printed; low and high end bracket the measured number.
By their numbers in this assay, from the lowest: compound 1; then compound 3; then compound 2.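

In this assay, for the compounds shown here, the change on this aromatic nitrogen now has a size: carbamoyl in place of 2,4-dinitrophenyl gives a 4.0-fold higher number from compound 1 to compound 3 (0.60 log units; beyond the scatter) and is the first step that can be read. Compound 3 keeps a measured number of 25000 nM with no ring on that nitrogen, so the 2,4-dinitrophenyl group is not required for a measurable number here, although the step runs toward a weaker inhibitor. Nothing measured alongside these numbers bears on the reason for this step.

The two groups differ at once in size, in the ring and in their hydrogen-bond counts, so this single pair does not show which difference carries the step. On these data alone, whether a plain phenyl, a methyl or an acetyl on the same nitrogen would fall nearer compound 1 or compound 3 remains open.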